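This account rests on a few compounds, and the source may have more. Where it says the series, first, only, none or still open, it means among the compounds named here.

In an assay on isolated protein for inhibition of sodium channel protein type 3 subunit alpha (Homo sapiens), read by electrophysiology, with a stated time of 4 min (a lower number here means a stronger inhibitor, a higher number a weaker inhibitor), compound 2 `CC(C)(C)OC(=O)n1cc(-c2ccc(NC(=O)[C@@H]3CCCN3)cc2)nc1N` gives 25000 nM. Its only companion, compound 1 `CC(C)(C)OC(=O)n1cc(-c2ccc(NC(=O)c3cc4ccccc4[nH]3)cc2)nc1N`, gives 22000 nM in this assay, and the step of a 1.1-fold higher number from compound 1 to compound 2 (0.06 log units; within the scatter) lies within the scatter, so the two compounds cannot be told apart on this number. Compound 3 `CC(C)(C)OC(=O)n1cc(-c2ccc(NC(=O)[C@H]3CCCN3)cc2)nc1N` is the mirror form of compound 2 at a single point: the two compounds have the same atoms and bonds and differ only in configuration as drawn: 1 of 1 stereo elements differ; a stereocentre at a saturated ring carbon is drawn S in compound 2 and R in compound 3. No measured step bears on a change of this kind; the one step shown, a 1.1-fold higher number from compound 1 to compound 2 (0.06 log units; within the scatter), swaps the whole group on the carbonyl carbon without moving the number beyond the scatter, and it says nothing about inverting a stereocentre. Without a guide, the expected step of no change at the digits printed from compound 2 to compound 3 (within the scatter) is no larger than the scatter, though a real shift in either direction cannot be ruled out. Compound 3 is therefore estimated at 25000 nM in this assay, with a range from 7000 nM to 90000 nM.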

Compound 3, half-maximal inhibitory concentration: > 30000 nM
Compound 3 ended at the assay's limit (the forecaster's own chance of this, stated with the estimate: 15%); at least 1.2-fold (0.07 log units) between middle value and limit.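

Among the compounds shown here, the pair of compound 2 and compound 3 is the first look at the handedness of this saturated ring carbon, and inverting it gives an at least 1.2-fold higher number from compound 2 to compound 3 (0.07 log units; that floor lies within the scatter), while the swap of 1H-indol-2-yl for this pyrrolidin-2-yl form gives an at least 1.3-fold higher number from compound 1 to compound 3 (0.13 log units; that floor lies within the scatter). In this assay compound 3 gives > 30000 nM, which is a limit of the assay and not a number. The inversion may have changed nothing or may have moved the number well past these floors, and the true size of the step cannot be read because of where the reading stops: the limit of > 30000 nM in this assay, at which 1 of the 3 values shown sits.

Still open, from the compounds shown here alone, is whether the two mirror forms differ at all once both readings fall inside the range of the assay. A piperidin-2-yl ring or an open-chain amine on the carbonyl carbon might bring the numbers down far enough to show this.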